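Swapping a fluorophenyl for a cyanopyridyl on the piperidine carbon

This account rests on a few compounds, and the source may have more. Where it says the series, first, only, none or still open, it means among the compounds named here.

Of the compounds shown here, three sharing a basic six-membered ring have been tested in a functional assay on HEK293 cells for agonist activity at D(4) dopamine receptor (Homo sapiens), read by FLIPR; a higher number here means that more compound is needed for the effect, a lower number that less compound is needed. Compound 1 `Cc1cccc(NC(=O)CN2CCC(c3cccc(F)c3)CC2)c1` gives 512 nM, the highest of the three numbers. Compound 2 `O=C(CN1CCC(c2cccc[n+]2[O-])CC1)Nc1cccc(F)c1` gives 160 nM, and compound 3 `[O-][n+]1ccccc1C1CCN(Cc2nc3ccccc3[nH]2)CC1` gives 54 nM; both lie beyond the usual scatter from compound 1, and compound 3 is the furthest away. Since compound 2 and compound 3 differ from compound 1 in more than one place, no single step can be read from these pairs.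

Compound 4 `Cc1cccc(NC(=O)CN2CCC(c3cccc(C#N)n3)CC2)c1` has not yet been measured. It differs from compound 1 in one place: 6-cyanopyridin-2-yl in place of 3-fluorophenyl on a saturated ring carbon. Compound 2, which also carries a nitrogen-containing six-membered ring at that saturated carbon, gives 160 nM, a lower number than compound 1, which hints that such a ring may be tolerated there. Within the data shown here, with no direct step available, the expectation is a modest move to a lower number, estimated as a 2.0-fold lower number from compound 1 to compound 4 (0.29 log units; within the scatter). Compound 4 is expected to give 260 nM, within a range from 80 nM to 850 nM.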

Compound 4, half-maximal effective concentration: 36 nM
The estimate for compound 4 lay 7.2-fold (0.86 log units) above the measured number, outside the stated range (below it).
By their numbers in this assay, from the lowest: compounds 4 and 3 (each within the scatter of the next); then compound 2; then compound 1.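

At the saturated ring carbon of the shared core, the group carried there has a strong influence on the result: in this assay, placing 6-cyanopyridin-2-yl there in place of 3-fluorophenyl gives a 14-fold lower number from compound 1 to compound 4 (1.15 log units; beyond the scatter). Everything else in the molecule stays the same. Among these compounds, this is the first direct reading of this position, and it shows that much less compound is needed with the new group. Nothing available here explains the size of this gain.

As far as these compounds go, the step swaps several features at once, since a ring nitrogen and a nitrile enter together as the fluorine leaves, so the share of each remains unknown. A plain pyridin-2-yl ring without the nitrile, or a phenyl ring carrying a nitrile, would be needed to separate the two.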